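A few compounds are considered here, and "the series" means these few. Any claim that something is new, unique, unknown or untested is made for them only; others in the source may bear on it.

Compounds with measured values:
compound 1, `COc1ccc(-c2nc(C(F)(F)F)n(CC[C@@H](O)C[C@@H](O)CC(=O)O)c2-c2ccc(F)cc2)cc1`, 68 nM;
compound 2, `CC(C)c1nc(-c2ccc(F)cc2)c(-c2ccc(F)cc2)n1CC[C@@H](O)C[C@@H](O)CC(=O)O`, 316 nM;
compound 3, `O=C(O)C[C@H](O)C[C@H](O)CCn1c(C(F)(F)F)nc(-c2ccc(F)cc2)c1-c1ccccc1`, 201 nM.

All three were tested in an assay on microsomes from liver for inhibition of 3-hydroxy-3-methylglutaryl-coenzyme A reductase (Rattus norvegicus); on this read-out lower numbers stand for stronger inhibition and higher numbers for weaker inhibition. Compound 1 gives the lowest of the three numbers, with 68 nM. Compound 3, with 201 nM, stands second highest; its nearest neighbour is compound 2 at 316 nM, a gap that lies within the scatter of the assay, so no order between compounds 2 and 3 can be read from it. The gap from compound 3 to compound 1 is larger and lies beyond the scatter, so compound 1 inhibits more strongly than compound 3.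

Compound 4, `Cc1cc(-c2c(-c3ccc(F)cc3)nc(C(F)(F)F)n2CC[C@@H](O)C[C@@H](O)CC(=O)O)cc(C)c1F`, has not yet been measured. It differs from compound 3 in one place: 4-fluoro-3,5-dimethylphenyl in place of phenyl on an aromatic carbon. Among the compounds with values here, no pair of measured compounds shows this same change, so its effect is not known from the data. Compound 1 carries substituted aromatic rings on both carbons of the shared core and gives 68 nM, which offers a loose hint that a substituted ring may be tolerated or favourable. On that basis compound 4 is expected to show a modest decrease in number, with the step of a 1.8-fold lower number from compound 3 to compound 4 (0.26 log units; within the scatter) probably near the edge of the scatter. The estimate for compound 4 in this assay is 110 nM, within a range from 40 nM to 300 nM.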

Compound 4, half-maximal inhibitory concentration: 31 nM
Compound 4: middle estimate off by 3.5-fold (0.55 log units), on the high side, and the stated range ends above it.
By their numbers in this assay, from the lowest: compound 4; then compound 1; then compounds 3 and 2 (each within the scatter of the next).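

In this assay, putting 4-fluoro-3,5-dimethylphenyl in place of phenyl gives a 6.5-fold lower number from compound 3 to compound 4 (0.81 log units; beyond the scatter), a step beyond the scatter. Within the data shown here, this is the first direct reading at this aromatic carbon, next to the ring nitrogen and next to the ring atom that bears a 4-fluorophenyl group: the substituted ring is not merely accepted here, and the number responds clearly to what the phenyl ring carries, with everything else in the molecule held the same. No measurement at hand accounts for the size of this step.

The single step changes the ring in several ways at once, so the compounds shown do not tell whether the methyl groups, the fluorine or their combination carries the effect, a question that 4-fluorophenyl or 3,5-dimethylphenyl at this carbon would help to separate. They also leave open how far the trend extends on this ring, for instance with a chlorine, a methoxy group or an amine in these places, and whether the same change would give a similar step with isopropyl in place of trifluoromethyl on the shared core.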